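Ester Variation on a Shared Urotensin-2 Receptor Core

A few compounds are considered here, and "the series" means these few. Any claim that something is new, unique, unknown or untested is made for them only; others in the source may bear on it.

Measured compounds:
compound 1 `CN(C)CCC(OC(=O)c1ccc(C(F)(F)F)cc1)c1ccc(Cl)cc1`: 47%
compound 2 `CN(C)CCC(OC(=O)c1ccc2ccccc2c1)c1ccc(Cl)cc1`: 49%
compound 3 `CCc1ccccc1C(=O)OC(CCN(C)C)c1ccc(Cl)cc1`: 128%

Three esters built on one shared core were measured in an assay on NIH3T3 cells with Urotensin-2 receptor (Homo sapiens) as the target; on this read-out lower numbers stand for smaller maximal responses and higher numbers for larger maximal responses. Compound 3 stands highest of the three numbers; its nearest neighbour is compound 2, whose value lies lower by a gap beyond the scatter, and compound 1 lies lower still, also beyond the scatter. Compound 1 and compound 2 sit close to one another.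

The next compound, compound 4 `Cc1ccc(C(=O)OC(CCN(C)C)c2ccc(Cl)cc2)cc1`, has not yet been measured in this assay. It differs from compound 3 in a single place: 4-methylphenyl in place of 2-ethylphenyl on a carbonyl carbon. Within the data shown here, no step between measured compounds matches this change, so the expectation rests on the spread of the three values. Since compound 1 gives 47% and compound 2 gives 49% while only compound 3 reaches 128%, the high value looks tied to the 2-ethylphenyl that leaves. For compound 4 a drop beyond the scatter is therefore expected, a number 66 percentage points lower from compound 3 to compound 4 (beyond the scatter). Compound 4 is estimated at 62%, within a range from 40% to 95%.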

Compound 4, largest response reached (reported as efficacy), in percent of the reference or control that the assay uses: 56%
For compound 4 the middle estimate is 6 percentage points above the measured one; the measured number falls inside the stated range.
By their numbers in this assay, from the lowest: compounds 1, 2 and 4 (each within the scatter of the next); then compound 3.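

In this assay, 4-methylphenyl in place of 2-ethylphenyl on a carbonyl carbon gives a number 72 percentage points lower from compound 3 to compound 4 (beyond the scatter), the first step read directly at this position, and it shows that the high value of compound 3 does not survive this single change. Methyl in place of trifluoromethyl on an aromatic carbon gives a number 9 percentage points higher from compound 1 to compound 4 (within the scatter), so these two groups are not told apart on this read-out. Nothing at hand accounts for either step. The compounds shown leave open whether the high value depends on the ethyl group itself, and a propyl chain or a methoxy group in its place on the phenyl ring would test that. They also leave open whether an amide link in place of the ester would keep the value of compound 3.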